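A Bromo Core Series in a Cellular Cytotoxicity Assay

The source may hold more compounds than are shown below. What is called first, only, known or untested is meant among the compounds shown, and "the series" means these compounds.

Compound 1 `N[C@H]1CC[C@H](Nc2c(C(=O)NCc3ccc(F)cc3)nc(N3CCCCC3)c3cccnc23)CC1`: 5000 nM
Compound 2 `O=C(NCc1ccc(F)cc1)c1nc(Br)c2cccnc2c1NCCCNc1c(C(=O)NCc2ccc(F)cc2)nc(Br)c2cccnc12`: > 20000 nM
Compound 3 `NCCNc1c(C(=O)NCc2ccc(F)cc2)nc(Br)c2cccnc12`: 12000 nM

Of the compounds shown here, three sharing a common core have been tested in a functional assay on MDA-MB-435 cells (Homo sapiens) for cytotoxicity, read by MTT assay, with a stated time of 72 h; a lower number here means a stronger inhibitor, a higher number a weaker inhibitor. Compound 1 gives 5000 nM in this assay. Compound 2 reaches only a limit of this assay, > 20000 nM, a value at which one of the three results sits (the limit of > 20000 nM in this assay, at which 1 of the 3 values shown sits). Compound 3 gives 12000 nM in this assay, the highest of the two numbers given; its nearest neighbour is compound 1, whose number lies lower by a gap beyond the usual scatter.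

Compound 4 `O=C(NCc1ccc(F)cc1)c1nc(Br)c2cccnc2c1NCc1ccc(F)cc1` has not yet been measured in this assay. It differs from compound 3 in one place: 4-fluorophenyl in place of aminomethyl on a saturated chain carbon bound to a nitrogen on an aromatic ring. The (2-aminoethyl)amino group of compound 3 thus becomes a (4-fluorobenzyl)amino group, and a second 4-fluorophenyl ring enters the molecule. Going by the values given here, no measured pair shows this kind of change, so the direction of the step rests on expectation alone. The step from compound 3 to compound 4 in this assay is estimated at a 1.5-fold higher number from compound 3 to compound 4 (0.18 log units; within the scatter), a modest move toward a weaker inhibitor, and compound 4 is expected to give about 18000 nM, within a range of 5000 nM to 50000 nM.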

Compound 4, half-maximal inhibitory concentration: > 20000 nM
Compound 4 ended at the assay's limit; the forecaster's own chance of this, stated with the estimate: 35%; at least 1.1-fold (0.04 log units) between middle value and limit.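

Going by these compounds alone, this is the first measured step at this position: in this assay, 4-fluorophenyl in place of aminomethyl on a saturated chain carbon bound to a nitrogen on an aromatic ring gives an at least 1.6-fold higher number from compound 3 to compound 4 (0.22 log units; that floor lies within the scatter). Within the data shown here, the value of compound 4 is a limit of the assay and not a number, so this step is only a floor, and it shows only that the second 4-fluorophenyl ring brought no lower number. The series now meets this limit more than once: the limit of > 20000 nM in this assay, at which 2 of the 4 values shown sit.

From the compounds shown here alone, how far the true value of compound 4 lies past the limit remains open, so the full size of the step cannot be read. Also open, going by these compounds, is whether a longer chain ending in an amine, or a carboxylic acid in place of aminomethyl, would take the number below that of compound 3 at 12000 nM.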